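Thioether variation on the shared core: compound 3

The compounds below may be only part of what the source reports. "The series", "measured", "known", "first", "only" and "open" are said of these compounds alone.

Going by the values given here, compound 1 `Cc1cc(Nc2cc(-c3ccccc3)[nH]n2)n2nc(SCC3CCCCC3)nc2n1` is the weaker of the two measured members. Among the compounds with values here, in a functional assay on MGC-803 cells (Homo sapiens) for inhibition, read by MTT assay, with a stated time of 72 h (on this read-out lower numbers stand for stronger inhibition and higher numbers for weaker inhibition), compound 1 gives 12600 nM, the highest of the two numbers so far, while compound 2 `Cc1cc(Nc2ccn(Cc3ccc(F)cc3)n2)n2nc(SCc3ccc(Br)cc3)nc2n1` gives 3070 nM in this assay. Compound 2 differs from compound 1 in several places at once, so its lower number cannot be tied to any single change; it only shows that a thioether bearing an aromatic ring is compatible with a lower reading in this assay.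

Compound 3 `Cc1ccc(CSc2nc3nc(C)cc(Nc4cc(-c5ccccc5)[nH]n4)n3n2)cc1` follows from compound 1 by one change: 4-methylphenyl in place of cyclohexyl on a saturated chain carbon bound to a sulfur. The rest of the molecule is unchanged.

Within the data shown here, no pair differing in one place has been measured, so the size of this step is open. The expectation is a modest move toward a lower number, of a size that may or may not clear the scatter, and the step from compound 1 to compound 3 is estimated at a 1.8-fold lower number from compound 1 to compound 3 (0.26 log units; within the scatter) in this assay. For compound 3 the estimated value in this assay is 7000 nM, with a range from 2500 nM to 20000 nM.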

Compound 3, half-maximal inhibitory concentration: 6960 nM
Compound 3: middle estimate off by 1.0-fold (0.00 log units), on the high side; the measured number falls inside the stated range.
By their numbers in this assay, from the lowest: compound 2; then compounds 3 and 1 (each within the scatter of the next).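

Going by these compounds alone, this is the first step that changes one place only, and in this assay it reads a 1.8-fold lower number from compound 1 to compound 3 (0.26 log units; within the scatter). On a saturated chain carbon bound to a sulfur, 4-methylphenyl therefore takes the place of cyclohexyl with no reading that can be separated from that of compound 1, so on this read-out the position accepts either a six-membered aromatic ring or a six-membered non-aromatic ring of carbon only. No independent measurement on these compounds bears on this step or gives any reason for its size.

Open, on these data alone, is whether a plain benzyl, a 4-methoxybenzyl or a longer chain such as 2-phenylethyl on the sulfur, or an amine or a carboxylic acid on the ring of the 4-methylbenzyl group, would produce a step beyond the scatter. The thioether of compound 2 also cannot be weighed against that of compound 3 from these numbers, as the two compounds differ in several places at once.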